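Dimethylamino in place of chloro: next step in the series

The compounds below may be only part of what the source reports. "The series", "measured", "known", "first", "only" and "open" are said of these compounds alone.

For the measured compounds named here, compound 3 `O=c1oc2ccccc2cc1C1=NN(c2ccccc2)[C@@H](c2ccc(Cl)cc2)C1` gives 64.7% in a functional assay on the whole organism (strain albino) for inhibition, with Rattus norvegicus as the target, read by paw edema, with stated times of 1 h and 4 h, at a dose of 200 mg/kg by the oral route (a higher number here means more inhibition at the dose given (going by the name of the read-out), a lower number less inhibition), the highest of the three numbers measured so far. Compound 1 `O=c1oc2ccccc2cc1C1=NN(c2ccccc2)[C@@H](c2ccccc2)C1` gives 32.7% and compound 2 `COc1ccc([C@H]2CC(c3cc4ccccc4oc3=O)=NN2c2ccccc2)cc1` gives 36.2%; the steps up from each of them are beyond the scatter: a number 32 percentage points higher from compound 1 to compound 3 (beyond the scatter) and a number 28.5 percentage points higher from compound 2 to compound 3 (beyond the scatter). By contrast a number 3.5 percentage points higher from compound 1 to compound 2 (within the scatter) lies within the scatter. Compound 4 `CN(C)c1ccc([C@H]2CC(c3cc4ccccc4oc3=O)=NN2c2ccccc2)cc1` carries dimethylamino in place of chloro on an aromatic carbon. Going by the values given here, no measured step involves dimethylamino. The two steps that bear on the change, both bringing chloro in, were large, and chloro is now the group leaving; the hydrogen and methoxy analogues stand well below. A fall back toward that level is therefore expected. The expected step is a number 24.7 percentage points lower from compound 3 to compound 4 (beyond the scatter). Compound 4 is estimated at 40%, with a range from 25% to 58%.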

Compound 4, a percentage reported as inhibition, in the whole organism at one dose (the size of the read-out at that dose, not a potency): 40.1%
For compound 4 the middle estimate is 0.1 percentage points below the measured one, and the stated range covers the measured number.
By their numbers in this assay, from the lowest: compounds 1, 2 and 4 (each within the scatter of the next); then compound 3.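

In this assay, a number 24.6 percentage points lower from compound 3 to compound 4 (beyond the scatter), so the rise seen with chloro at this position does not carry over to dimethylamino. Dimethylamino stays level with the other two groups, with a number 3.9 percentage points higher from compound 2 to compound 4 (within the scatter) and a number 7.4 percentage points higher from compound 1 to compound 4 (within the scatter), which leaves chloro as the only one of the four groups that stands apart. Nothing available on these compounds explains this difference.

Open, as far as these compounds go, is whether the rise is particular to chloro or extends to fluoro, bromo or trifluoromethyl at the same place on the ring.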